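Swapping a Terminal Phenyl for a Hydroxy Group

The compounds below may be only part of what the source reports. "The series", "measured", "known", "first", "only" and "open" are said of these compounds alone.

Of the compounds shown here, three sharing one core have been measured in an assay on mitochondria (strain BALB/c) for inhibition of glycerol-3-phosphate acyltransferase 1, mitochondrial (Mus musculus), read by scintillation counting, with a stated time of 10 min; a higher number here means a weaker inhibitor, a lower number a stronger inhibitor. Compound 1 `CCCCCCCCS(=O)(=O)Nc1cc(-c2ccc(CCCC)cc2)ccc1C(=O)O` gives 15700 nM. Compound 2 `CCCCCCCCS(=O)(=O)Nc1cc(-c2ccccc2-c2ccccc2)ccc1C(=O)O` gives 17100 nM. Compound 3 `CCCCCCCCS(=O)(=O)Nc1cc(-c2ccc(-c3ccccc3)cc2)ccc1C(=O)O` gives 13500 nM, the lowest of the three numbers, yet its gaps to compound 1 and to compound 2 both lie within the scatter, so the three cannot be told apart. Among the measured compounds shown here, the only single-point step recorded is a 1.2-fold lower number from compound 1 to compound 3 (0.07 log units; within the scatter), which changes nothing that this assay can resolve.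

Compound 4 `CCCCCCCCS(=O)(=O)Nc1cc(-c2ccc(O)cc2)ccc1C(=O)O` is not yet measured. It differs from compound 3 by hydroxy in place of phenyl on an aromatic carbon. For the measured compounds named here, no measured step involves a hydroxy group; the one step that exchanges the group at this place, a 1.2-fold lower number from compound 1 to compound 3 (0.07 log units; within the scatter), swaps one carbon-only group for another and stays within the scatter. Going by the values given here, the present change therefore has no close precedent. All three measured compounds carry a sizeable group at this position, and the new one is much smaller by the count given, so the outcome is uncertain; the expectation leans toward a somewhat higher number, that is a weaker inhibitor, with a 2.2-fold higher number from compound 3 to compound 4 (0.35 log units; beyond the scatter). Compound 4 is accordingly estimated at 30000 nM, in a range from 12000 nM to 80000 nM.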

Compound 4, half-maximal inhibitory concentration: 64800 nM
The estimate for compound 4 lay 2.2-fold (0.33 log units) below the measured number; the measured number falls inside the stated range.
By their numbers in this assay, from the lowest: compounds 3, 1 and 2 (each within the scatter of the next); then compound 4.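

In this assay, this position at first seemed insensitive, since exchanging butyl for phenyl moved the number only within the scatter, but the new steps go beyond it: a 4.8-fold higher number from compound 3 to compound 4 (0.68 log units; beyond the scatter), and a 4.1-fold higher number from compound 1 to compound 4 (0.62 log units; beyond the scatter). The group here does matter, then, and the two steps agree that hydroxy gives a weaker inhibitor than either of the two carbon-only groups. Nothing measured here explains why this happens, so the drop in inhibition stands as an observation only.

This change removes a large group and brings in a hydrogen-bond donor and acceptor at the same time, so the compounds shown cannot say which of the two goes with the weaker inhibition; a methyl or a methoxy group at this place would help to separate them. Going by these compounds, it also remains open whether an amine, a carboxylic acid or a longer chain here would keep the numbers of compound 1 and compound 3 or move them further.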